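A few compounds are considered here, and "the series" means these few. Any claim that something is new, unique, unknown or untested is made for them only; others in the source may bear on it.

The compounds measured so far:

compound 1 `Cc1ccc(NC2=CC(=O)c3c(nc4n3[C@H]3OC[C@@H](O)[C@H]3OC4)C2=O)cc1C` gives 4090 nM in a functional assay on ECa-109 cells for inhibition, with ECa-109 cell line (Homo sapiens) as the target, read by sulforhodamine B assay; a higher number here means a weaker inhibitor, a lower number a stronger inhibitor
compound 2 `COc1ccc(NC2=CC(=O)c3c(nc4n3[C@H]3OC[C@@H](O)[C@H]3OC4)C2=O)cc1` gives 3410 nM in this assay
compound 3 `O=C1C=C(Nc2ccc(C(F)(F)F)cc2)C(=O)c2c1nc1n2[C@H]2OC[C@@H](O)[C@H]2OC1` gives 5500 nM in this assay

All three share one core and differ only in the aryl group on the amine nitrogen. Compound 3 carries the highest of the three numbers, yet its separation from compound 1 and from compound 2 is within the scatter, so the three cannot be ordered with confidence.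

Compound 4 `O=C1C=C(Nc2ccccc2F)C(=O)c2c1nc1n2[C@H]2OC[C@@H](O)[C@H]2OC1` is not yet measured. It differs from compound 3 in one place: 2-fluorophenyl in place of 4-(trifluoromethyl)phenyl on an amine nitrogen.

Among the compounds with values here, the only measured step that bears on this kind of change is the aryl swap a 1.2-fold lower number from compound 1 to compound 2 (0.08 log units; within the scatter), which stayed within the scatter. Since one aryl-for-aryl exchange on this nitrogen moved the number so little, and since all three measured aryl variants sit within the scatter of each other, no step beyond the scatter is expected for compound 4 in this assay. Compound 4 is therefore estimated at 4500 nM, with a range from 2000 nM to 10000 nM, which corresponds to an expected step of a 1.2-fold lower number from compound 3 to compound 4 (0.09 log units; within the scatter).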

Compound 4, half-maximal inhibitory concentration: 2760 nM
Beside the measured number, compound 4's estimate is 1.6-fold (0.21 log units) above it, and the stated range covers the measured number.
By their numbers in this assay, from the lowest: compounds 4, 2, 1 and 3 (each within the scatter of the next).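

In this assay, the exchange of 4-(trifluoromethyl)phenyl for 2-fluorophenyl on the amine nitrogen gives a 2.0-fold lower number from compound 3 to compound 4 (0.30 log units; within the scatter), a step that stays within the scatter. Within the data shown here, the earlier compounds showed only one such exchange, and this one adds a smaller aryl group, so the position now shows no step beyond the scatter across four aryl groups. No evidence is available to explain this step.

The compounds shown leave open whether a step beyond the scatter appears when the aryl group gives way to a non-aromatic group, such as a cyclohexyl ring or a longer alkyl chain. They also leave open what a carboxylic acid or an amine on the phenyl ring would do at this nitrogen.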